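Swapping methoxy for fluoro on a hydroxamic acid

This account rests on a few compounds, and the source may have more. Where it says the series, first, only, none or still open, it means among the compounds named here.

Measured compounds:
compound 1, `COc1ccc(-c2nc(CNc3ccc(C(=O)NO)cc3)n(-c3ccccc3)n2)cc1`, 163 nM
compound 2, `Cc1ccc(-n2nc(-c3ccccc3)nc2CNc2ccc(C(=O)NO)cc2)cc1`, 310 nM
compound 3, `COc1ccc(-n2nc(-c3ccc(O)cc3)nc2CNc2ccc(C(=O)NO)cc2)cc1`, 102 nM

Of the compounds shown here, three sharing one core have been tested in an assay on Sf9 cells for inhibition of protein deacetylase HDAC6 (Homo sapiens), read by fluorescence, with a stated time of 40 min; a lower number here means a stronger inhibitor, a higher number a weaker inhibitor. Compound 1 gives 163 nM, compound 3 gives 102 nM, and compound 2 gives 310 nM. Compound 1 differs from compound 3 and from compound 2 by less than the usual scatter in each case, so the three numbers cannot be told apart with confidence; none of them can be called the strongest or the weakest inhibitor.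

The step of interest leads from compound 1 to compound 4, `O=C(NO)c1ccc(NCc2nc(-c3ccc(F)cc3)nn2-c2ccccc2)cc1`, which has not yet been measured in this assay. The change is fluoro in place of methoxy on an aromatic carbon. Within the data shown here, no pair of measured compounds differs in a single place, so nothing here shows how large such a change can be. In this assay the step from compound 1 to compound 4 is expected to be small, with no direction beyond the scatter, a 1.1-fold higher number from compound 1 to compound 4 (0.04 log units; within the scatter). Compound 4 is therefore estimated at 180 nM, within a range from 70 nM to 450 nM.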

Compound 4, half-maximal inhibitory concentration: 115 nM
Compound 4: the middle estimate sits 1.6-fold (0.19 log units) above what was measured, and the stated range covers the measured number.
By their numbers in this assay, from the lowest: compounds 3, 4, 1 and 2 (each within the scatter of the next, the first and the last beyond it).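

In this assay, among these compounds, the change from 4-methoxyphenyl to 4-fluorophenyl gives the first comparison here between compounds that differ in one place: the step is a 1.4-fold lower number from compound 1 to compound 4 (0.15 log units; within the scatter) and lies within the usual scatter. At this position, on an aromatic carbon para to a large group, fluoro can therefore stand in for methoxy with no change the assay can resolve, even though one heavy atom replaces two and the hydrogen-bond acceptor counted for methoxy is lost. No supporting data are available to say why the number holds.

One step cannot show how much variation this position accepts overall. An amine, a carboxylic acid or a longer chain such as butoxy in the same place could behave quite differently, and the compounds shown do not settle that.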